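Removing the cinnamoyl arm from an anilide benzophenone

The compounds below may be only part of what the source reports. "The series", "measured", "known", "first", "only" and "open" are said of these compounds alone.

Compound 1 `COc1ccc(/C=C/C(=O)Nc2cc(C(=O)c3cc(OC)c(OC)c(OC)c3)cc(OC)c2OC)cc1` gives 6300 nM
Compound 2 `COc1cc(C(=O)c2cc(OC)c(OC)c(OC)c2)cc(NC(=O)/C=C/c2ccc(C(F)(F)F)cc2)c1OC` gives 4200 nM
Compound 3 `COc1cc(C(=O)c2cc(OC)c(OC)c(OC)c2)cc(NC(=O)/C=C/c2cc(F)c(F)c(F)c2)c1OC` gives 7400 nM

Three amides sharing the core of compound 1 have been measured in a functional assay on PC-3 cells (Homo sapiens) for cytotoxicity, read by MTT assay, with a stated time of 72 h; on this read-out lower numbers stand for stronger inhibition and higher numbers for weaker inhibition. On these numbers compound 1 stands second highest of the three; its nearest neighbour is compound 3, and the step of a 1.2-fold higher number from compound 1 to compound 3 (0.07 log units; within the scatter) lies within the scatter, as do a 1.5-fold lower number from compound 1 to compound 2 (0.18 log units; within the scatter) and a 1.8-fold higher number from compound 2 to compound 3 (0.25 log units; within the scatter). All three measured steps exchange only the aryl group at the far end of the acrylamide chain, and none of them moves the number beyond the scatter.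

Compound 4 `COc1cc(C(=O)c2cc(OC)c(OC)c(OC)c2)cc(N)c1OC` is not yet measured. It differs from compound 1 by hydrogen in place of (2-(4-methoxyphenyl)ethenyl)carbonyl on a nitrogen on an aromatic ring. Among the measured compounds shown here, no measured step bears on this change: every recorded step keeps the amide and its double-bonded chain, whereas here the whole arm is lost and only the free amine remains on the ring. The three measured values give a cluster, but offer no direction for such a cut. Compound 4 is therefore expected near the cluster, with a wide range, the step of a 1.6-fold lower number from compound 1 to compound 4 (0.20 log units; within the scatter) being an estimate only; the value expected for compound 4 is 4000 nM, between 400 nM and 40000 nM.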

Compound 4, half-maximal inhibitory concentration: 7400 nM
Estimate against measurement, compound 4: 1.9-fold (0.27 log units) below; the measured number falls inside the stated range.
By their numbers in this assay, from the lowest: compounds 2, 1, 3 and 4 (each within the scatter of the next).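

Removing the whole (2-(4-methoxyphenyl)ethenyl)carbonyl arm from the nitrogen on the aromatic ring gives a 1.2-fold higher number from compound 1 to compound 4 (0.07 log units; within the scatter) in this assay. The earlier steps shown here exchanged only the aryl group on the arm, whereas this one shows that the full arm, with its 12 heavy atoms, can give way to hydrogen without the number leaving the scatter, so the free amine compound 4 cannot be told apart from the amides. Nothing at hand explains this result.

The compounds shown leave open whether any group on this nitrogen can move the number beyond the scatter, for example an acetyl group, a methyl group or a longer chain without an aryl group. They also leave open how far the number depends on the methoxy groups of the shared core, which stay the same throughout.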